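The source may hold more compounds than are shown below. What is called first, only, known or untested is meant among the compounds shown, and "the series" means these compounds.

Compound 1 `C=C1c2c(C)nc(OC)c(C#N)c2N=CN1CCCCCC` is tested in a functional assay on KB cells (Homo sapiens) for cytotoxicity, read by MTT assay, with a stated time of 3 days; on this read-out higher numbers stand for weaker inhibition and lower numbers for stronger inhibition. In this assay compound 1 gives > 50000 nM, which is a limit of the assay and not a number. Compound 1 thus stands at the limit of > 50000 nM in this assay, at which 2 of the 3 values shown sit, so its place among the three measured compounds cannot be read more closely. Compound 2 `C=C1c2c(C)nc(OC)c(C#N)c2N=CN1Cc1ccccc1` likewise reaches only a limit in this assay, namely > 50000 nM. Compound 3 `C=C1c2c(C)nc(OC)c(C#N)c2N=CN1Cc1ccc(C)cc1` gives 480 nM in this assay. The step that the two limits leave unreadable from compound 1 to compound 2, whereas an at least 100-fold lower number from compound 1 to compound 3 (2.01 log units; beyond the scatter) and an at least 100-fold lower number from compound 2 to compound 3 (2.01 log units; beyond the scatter).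

Compound 4 `C=C1c2c(C)nc(OC)c(C#N)c2N=CN1Cc1ccc(OC)cc1` is the next compound and differs from compound 1 by 4-methoxyphenyl in place of pentyl on a saturated chain carbon bound to an amine nitrogen in a ring. For the measured compounds named here, two measured steps bear on it: an aromatic ring entering in place of pentyl gave an at least 100-fold lower number from compound 1 to compound 3 (2.01 log units; beyond the scatter) when the ring carried a methyl, yet a step that the two limits leave unreadable from compound 1 to compound 2 when the ring was bare phenyl. A methoxy group on the ring makes compound 4 resemble compound 3 more than compound 2, so a large fall in the number is expected in this assay, though a limit cannot be excluded. Compound 4 is estimated at 1500 nM, with a range from 300 nM to 50000 nM, which means an expected step of an at least 33-fold lower number from compound 1 to compound 4 (1.52 log units; beyond the scatter).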

Compound 4, half-maximal inhibitory concentration: 670 nM
Compound 4: the middle estimate sits 2.2-fold (0.35 log units) above what was measured; the range from low to high includes it.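

Methyl is no longer the only ring substituent tied to a large fall, since a methoxy group on the bare phenyl ring gives an at least 74-fold lower number from compound 2 to compound 4 (1.87 log units; beyond the scatter). The change from pentyl to 4-methoxyphenyl likewise gives an at least 74-fold lower number from compound 1 to compound 4 (1.87 log units; beyond the scatter), so among these compounds both substituted rings go with a large fall, while bare phenyl, in compound 2, stays at a limit. In this assay, methoxy in place of methyl gives a 1.4-fold higher number from compound 3 to compound 4 (0.14 log units; within the scatter), so the two groups cannot be told apart here.

Going by these compounds, the true sizes of the large steps remain open because the comparison starts from a limit: the limit of > 50000 nM in this assay, at which 2 of the 4 values shown sit. Also open, on these data alone, is whether a chlorine, an amine or a carboxylic acid on the aromatic ring would go with a similar fall.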